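The source may report more compounds than this note shows. Statements on the series, on what has been measured and on what is new or still open speak of the compounds shown alone.

Measured so far:
Compound 1 `CC(C)C(=O)OCOC(=O)C1=C(S[C@@H]2CN[C@H](C(=O)Nc3cccc(C(=O)OCOC(=O)C(C)C)c3)C2)[C@H](C)[C@@H]2[C@@H]([C@@H](C)O)C(=O)N12` gives > 95%.
Compound 2 `CC(C)OC(=O)OCOC(=O)C1=C(S[C@@H]2CN[C@H](C(=O)Nc3cccc(C(=O)O)c3)C2)[C@H](C)[C@@H]2[C@@H]([C@@H](C)O)C(=O)N12` gives > 95%.

In a physicochemical assay for metabolic stability, read by LC-MS, in phosphate buffer, with a stated time of 3 h, at pH 7.4, tested at 50 uM (a higher number here means that more of the compound is left, a lower number that less of the compound is left), compound 1 gives > 95%, which is a limit of the assay rather than a number. Compound 2 likewise returns a value that is a limit, > 95%. Compound 1 thus stands at the limit of > 95% in this assay, at which 2 of the 2 values shown sit, so no ordering among the measured compounds can be read from these figures. Compound 3 `CC(C)C(=O)OCOC(=O)c1cccc(NC(=O)[C@@H]2C[C@H](SC3=C(C(=O)O)N4C(=O)[C@H]([C@@H](C)O)[C@H]4[C@H]3C)CN2)c1` differs from compound 1 in one place: hydrogen in place of ((isopropylcarbonyl)oxy)methyl on an oxygen next to a carbonyl group. For the measured compounds named here, no measured pair carries this change, and with both measured values sitting at the limit, no step beyond the usual scatter is expected in either direction. Compound 3 is therefore expected to give about 96%, between 88% and 100%. That expectation means a step from compound 1 to compound 3 of a step that the limit leaves unreadable from compound 1 to compound 3, within the scatter.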

Compound 3, percent of the compound remaining: > 95%
Compound 3: a limit, no number (the forecaster's own chance of this, stated with the estimate: 80%); the middle value lies beyond the limit too.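

In this assay compound 3 gives > 95%, which is a limit and not a number; compound 1 also sits at a limit, so no step can be read between compound 1 and compound 3. The compounds shown leave open whether hydrogen in place of ((isopropylcarbonyl)oxy)methyl changes how much compound is left, as all they offer is this: the limit of > 95% in this assay, at which 3 of the 3 values shown sit.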